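Amine terminus variation on the shared ether core

This account rests on a few compounds, and the source may have more. Where it says the series, first, only, none or still open, it means among the compounds named here.

Compound 1 `c1ccc(COc2ccc(OCCOCCNc3cc[nH]c3)cc2)cc1` gives 11300 nM in a functional assay on SK-OV-3 cells (Homo sapiens) for inhibition, read by CCK-8 assay, with a stated time of 70 h; a lower number here means a stronger inhibitor, a higher number a weaker inhibitor.
Compound 2 `Nc1ccccc1COc1ccc(OCCOCCNC2CCCC2)cc1` gives 14000 nM.
Compound 3 `COc1ccc(OCCOCCNC2CCCC2)cc1` gives 99100 nM.

Compound 1 holds the lowest of the three numbers shown, but the gap to compound 2 is within the scatter, so the two cannot be ordered. For the measured compounds named here, only compound 3 stands clearly apart: the step of a 7.1-fold higher number from compound 2 to compound 3 (0.85 log units; beyond the scatter), which is hydrogen in place of 2-aminophenyl on a saturated chain carbon bound to an oxygen on an aromatic ring, is the one measured step in the set, and it concerns the ether end of the shared core, not the amine.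

Compound 4 `c1ccc(COc2ccc(OCCOCCNC3CC3)cc2)cc1` differs from compound 1 by cyclopropyl in place of 1H-pyrrol-3-yl on an amine nitrogen. Going by the values given here, no measured step bears directly on the amine nitrogen. Compounds 1 and 2 do carry different groups on that nitrogen, yet they also differ at the other end, and their two values lie within the scatter of each other; that pair therefore shows no sign of a large effect at the amine, though it settles nothing. With nothing beyond the scatter to point either way, the expected step for compound 4 is a 1.3-fold higher number from compound 1 to compound 4 (0.12 log units; within the scatter), that is, no step beyond the scatter. From the compounds shown here alone, compound 4 is thus estimated at 15000 nM, in a range from 5000 nM to 50000 nM, with the width reflecting that the amine position is untested.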

Compound 4, half-maximal inhibitory concentration: 47200 nM
The estimate for compound 4 lay 3.1-fold (0.50 log units) below the measured number; the range from low to high includes it.
By their numbers in this assay, from the lowest: compounds 1 and 2 (each within the scatter of the next); then compound 4; then compound 3.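

The amine nitrogen now has its first measured step: in this assay, cyclopropyl in place of 1H-pyrrol-3-yl gives a 4.2-fold higher number from compound 1 to compound 4 (0.62 log units; beyond the scatter). With the rest of the core of compound 1 unchanged, the group on this nitrogen therefore moves the number beyond the scatter, and the five-membered aromatic ring with its hydrogen-bond donor gives the lower number of this one pair. No measurement shown explains the step, and this single pair cannot separate the loss of the aromatic ring from the loss of the donor or the change in ring size.

Phenyl on the same nitrogen would keep an aromatic ring without that donor, while pyrrolidin-3-yl would keep a five-membered ring and a ring nitrogen without aromaticity, and neither is among the compounds shown. Also open, from the compounds shown here alone, is whether the step from 1H-pyrrol-3-yl to cyclopropyl holds when the benzyl ether end of the shared core carries a 2-aminophenyl group or is replaced by a methyl group.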